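Formyl to acetyl on the anilide of compound 2

A few compounds are considered here, and "the series" means these few. Any claim that something is new, unique, unknown or untested is made for them only; others in the source may bear on it.

Compound 1 `Nc1ccc(C2=NNC(=O)CC2)cc1`: in a functional assay for inhibition, with Homo sapiens as the target (on this read-out higher numbers stand for an effect only at larger amounts of compound and lower numbers for an effect already at smaller amounts), compound 1 gives 46.4 ug/mL.
Compound 2 `O=CNc1ccc(C2=NNC(=O)CC2)cc1`: in this assay compound 2 gives 3.74 ug/mL.

Among the compounds with values here, compound 2 stands lowest of the two numbers, and its only neighbour is compound 1: a 12-fold lower number from compound 1 to compound 2 (1.09 log units; beyond the scatter). Compound 3 `CC(=O)Nc1ccc(C2=NNC(=O)CC2)cc1` is not yet measured. It differs from compound 2 by methyl in place of hydrogen on a carbonyl carbon. Within the data shown here, the one measured step, a 12-fold lower number from compound 1 to compound 2 (1.09 log units; beyond the scatter), concerns the hydrogen on the nitrogen on an aromatic ring that the formyl replaced, not the carbonyl carbon that the methyl now joins, so it bears on the new step only loosely: it shows that a group on that nitrogen is tolerated and lowers the number. Among the measured compounds shown here, no measured pair tells what a methyl on that carbonyl carbon does. The expected step is therefore small, a 1.1-fold lower number from compound 2 to compound 3 (0.03 log units; within the scatter), within the scatter in either direction. Compound 3 is expected to give 3.5 ug/mL, between 1.2 ug/mL and 10 ug/mL.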

Compound 3, half-maximal effective concentration: 1 ug/mL
Estimate against measurement, compound 3: 3.5-fold (0.54 log units) above; measured number outside the range, below it.
By their numbers in this assay, from the lowest: compound 3; then compound 2; then compound 1.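

Methyl in place of hydrogen on this carbonyl carbon is not a neutral change in this assay: it gives a 3.7-fold lower number from compound 2 to compound 3 (0.57 log units; beyond the scatter), so this position matters as well as the nitrogen that carries the group. The effect of a group on that nitrogen therefore depends on which group it is, since acetyl in place of hydrogen gives a 46-fold lower number from compound 1 to compound 3 (1.67 log units; beyond the scatter), a larger step than the one formyl gave, a 12-fold lower number from compound 1 to compound 2 (1.09 log units; beyond the scatter). Nothing measured here explains why the added methyl lowers the number.

On these data alone, it remains open whether a longer chain on this carbonyl carbon, such as ethyl or propyl, would lower the number further or raise it again. What an amine or a methoxy group at the same place would do is also unknown.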